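Changing the Aryl Group on a Benzyloxy Side Chain

This account rests on a few compounds, and the source may have more. Where it says the series, first, only, none or still open, it means among the compounds named here.

Compound 1 `Cc1nn(-c2ncnc3nc[nH]c23)c2c1C(OCc1ccccc1F)CC(=O)N2` is measured in a functional assay on HEK293 cells for agonist activity at G-protein coupled receptor 39 (Homo sapiens), read by scintillation proximity assay and inositol phosphate accumulation, with a stated time of 75 min (a lower number here means that less compound is needed, a higher number that more compound is needed for the effect), where compound 1 gives 78 nM. That is the lowest of the three numbers recorded. Compound 2 `Cc1nn(-c2ncnc3nc[nH]c23)c2c1C(C(=O)NCc1ccccc1)CC(=O)N2`, which keeps the same core but carries a benzylcarbamoyl group in place of the (2-fluorobenzyl)oxy group, gives 2930 nM in this assay; the step is a 38-fold higher number from compound 1 to compound 2 (1.57 log units; beyond the scatter). Within the data shown here, compound 3 `Cc1cc(C)nc(-n2nc(C)c3c2NC(=O)CC3c2ccc(COc3cccc(Cl)c3)cc2)n1`, built on a different core, gives 3000 nM in this assay; its value lies far from that of compound 1 and close to that of compound 2, but no single step links compound 3 to either.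

Compound 4 `Cc1nn(-c2ncnc3nc[nH]c23)c2c1C(OCc1ccc(C(C)C)cc1)CC(=O)N2` differs from compound 1 by 4-isopropylphenyl in place of 2-fluorophenyl on a saturated chain carbon bound to an oxygen on a saturated carbon. Among the measured compounds shown here, the one measured step, from compound 1 to compound 2, alters the linker between the saturated ring carbon and the aromatic ring, not the substituent on the aromatic ring, so it does not bear directly on the change to compound 4. The benzyloxy linkage that sets compound 1 apart from compound 2 is retained in compound 4, which argues against a step as large as a 38-fold higher number from compound 1 to compound 2 (1.57 log units; beyond the scatter). Nothing in the measured set tells how the aromatic ring tolerates a different substituent, so the direction is open. For compound 4 the expected step is a 1.9-fold higher number from compound 1 to compound 4 (0.28 log units; within the scatter), a modest increase at most. Compound 4 is therefore estimated at 150 nM in this assay, within a range from 30 nM to 800 nM.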

Compound 4, half-maximal effective concentration: 1690 nM
Beside the measured number, compound 4's estimate is 11-fold (1.05 log units) below it; the whole stated range lies below it.
By their numbers in this assay, from the lowest: compound 1; then compounds 4, 2 and 3 (each within the scatter of the next).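

In this assay, the aryl group on the benzyloxy side chain matters: 4-isopropylphenyl in place of 2-fluorophenyl, on a saturated chain carbon bound to an oxygen on a saturated carbon, gives a 22-fold higher number from compound 1 to compound 4 (1.34 log units; beyond the scatter). The earlier step, a 38-fold higher number from compound 1 to compound 2 (1.57 log units; beyond the scatter), replaced the oxygen-linked side chain as a whole, whereas this one keeps the linkage and alters only the aryl group, and it is also large. Keeping the benzyloxy linkage is therefore not enough to retain the low number of compound 1, and no measured evidence explains why this aryl change has so large an effect.

The step removes the fluorine and introduces the isopropyl group at a different ring position in a single change, so the compounds shown do not separate the contribution of each. On these data alone, it remains open how an unsubstituted benzyl group or a 4-fluorobenzyl group would read at this place, and either would help show whether losing the 2-fluoro substituent or gaining the 4-isopropyl substituent accounts for the step.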